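The source may report more compounds than this note shows. Statements on the series, on what has been measured and on what is new or still open speak of the compounds shown alone.

Compound 1 `O=C(CSc1nc(Nc2ccccc2)c2ccccc2n1)Nc1ccccc1Cl` gives 9610 nM in a functional assay on NCI-H1975 cells (Homo sapiens) for inhibition, read by MTT assay, with a stated time of 72 h; a higher number here means a weaker inhibitor, a lower number a stronger inhibitor; compound 2 `O=C(CSc1nc(Nc2ccccc2)c2ccccc2n1)Nc1ccccc1Br` gives 10300 nM in this assay; compound 3 `O=C(CSc1nc(Nc2ccccc2)c2ccccc2n1)Nc1ccc([N+](=O)[O-])cc1` gives 13000 nM in this assay.

Compound 1 has the lowest number of the three, yet each of the other two lies within the scatter of it: a 1.1-fold higher number from compound 1 to compound 2 (0.03 log units; within the scatter) and a 1.4-fold higher number from compound 1 to compound 3 (0.13 log units; within the scatter). Compound 4 `O=C(CSc1nc(Nc2ccccc2)c2ccccc2n1)Nc1ccc(F)c(Cl)c1` is made from compound 1 by 3-chloro-4-fluorophenyl in place of 2-chlorophenyl on an amide-type nitrogen. For the measured compounds named here, no measured step matches this change exactly; the nearest comparisons are the exchanges of the aryl group on the amide-type nitrogen, a 1.4-fold higher number from compound 1 to compound 3 (0.13 log units; within the scatter) and a 1.3-fold higher number from compound 2 to compound 3 (0.10 log units; within the scatter), both within the scatter. A step of no more than the scatter is therefore expected in this assay, in no particular direction: a 1.1-fold higher number from compound 1 to compound 4 (0.06 log units; within the scatter). Compound 4 is estimated at 11000 nM, between 5000 nM and 25000 nM.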

Compound 4, half-maximal inhibitory concentration: 9390 nM
Estimate against measurement, compound 4: 1.2-fold (0.07 log units) above; low and high end bracket the measured number.
By their numbers in this assay, from the lowest: compounds 4, 1, 2 and 3 (each within the scatter of the next).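

The 3-chloro-4-fluorophenyl group, with two halogens on the ring, gives a number in this assay that stays within the scatter of all three earlier compounds (first a 1.0-fold lower number from compound 1 to compound 4 (0.01 log units; within the scatter); then a 1.1-fold lower number from compound 2 to compound 4 (0.04 log units; within the scatter); and a 1.4-fold lower number from compound 3 to compound 4 (0.14 log units; within the scatter)). Four different aryl groups on the amide-type nitrogen now give numbers that cannot be told apart. Nothing available offers an explanation for this.

From the compounds shown here alone, it remains open whether a carboxylic acid or an amine on this aryl ring, or a plain alkyl chain replacing the ring, would move the number beyond the scatter.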